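Moving a Methyl Around the Piperidine Ring

A few compounds are considered here, and "the series" means these few. Any claim that something is new, unique, unknown or untested is made for them only; others in the source may bear on it.

Compound 1, `COc1cc2c(Nc3nc4ccc(C(=O)Nc5c(C)cccc5Cl)cc4s3)ncnc2cc1OCCCN1CCC(C)CC1`, gives 8300 nM in a functional assay on K562 cells (Homo sapiens) for cytotoxicity, read by WST assay, with a stated time of 72 h; on this read-out higher numbers stand for weaker inhibition and lower numbers for stronger inhibition.
Compound 2, `COc1cc2c(Nc3nc4ccc(C(=O)Nc5c(C)cccc5C)cc4s3)ncnc2cc1OCCCN1CCC(C)CC1`, gives 15800 nM in this assay.
Compound 3, `COc1cc2c(Nc3nc4ccc(C(=O)Nc5c(C)cc(C)cc5C)cc4s3)ncnc2cc1OCCCN1CCC(C)CC1`, gives 5900 nM in this assay.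

Among these three numbers, compound 1 stands second highest. Its nearest neighbour is compound 3, reached by a 1.4-fold lower number from compound 1 to compound 3 (0.15 log units; within the scatter), and its furthest is compound 2, reached by a 1.9-fold higher number from compound 1 to compound 2 (0.28 log units; within the scatter). Going by the values given here, the only step beyond the scatter is a 2.7-fold lower number from compound 2 to compound 3 (0.43 log units; beyond the scatter), and it, like the other two, concerns the aryl group on the amide-type nitrogen.

Compound 4, `COc1cc2c(Nc3nc4ccc(C(=O)Nc5c(C)cccc5Cl)cc4s3)ncnc2cc1OCCCN1CCCCC1C`, is the unmeasured partner of compound 1. The difference is 2-methylpiperidin-1-yl in place of 4-methylpiperidin-1-yl on a saturated chain carbon, three bonds along the chain from an oxygen on an aromatic ring. Among the compounds with values here, none of the measured steps touches this part of the molecule, so no step bears directly on the change, and there is no ground for expecting a shift beyond the scatter in this assay. The estimate for compound 4 is therefore 8300 nM, with a range from 3000 nM to 23000 nM. The expected step is no change at the digits printed from compound 1 to compound 4 (within the scatter).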

Compound 4, half-maximal inhibitory concentration: 6800 nM
Compound 4: the middle estimate sits 1.2-fold (0.09 log units) above what was measured; the range from low to high includes it.
By their numbers in this assay, from the lowest: compounds 3, 4, 1 and 2 (each within the scatter of the next, the first and the last beyond it).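

Going by these compounds alone, compound 4 is the first compound here to vary the group on a saturated chain carbon, three bonds along the chain from an oxygen on an aromatic ring: 2-methylpiperidin-1-yl in place of 4-methylpiperidin-1-yl gives a 1.2-fold lower number from compound 1 to compound 4 (0.09 log units; within the scatter) in this assay and leaves the two compounds indistinguishable. With the 2-chloro-6-methylphenyl group kept on the amide-type nitrogen, moving the methyl around the piperidine ring therefore has no effect that can be told apart from ordinary repeat variation. Nothing available explains this result.

Going by these compounds, it remains open whether the same holds with the 2,4,6-trimethylphenyl group of compound 3 on that nitrogen. Also open, on these data alone, is how this position would respond to a larger change, such as 3-methylpiperidin-1-yl, unsubstituted piperidin-1-yl or morpholin-4-yl in the same place.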